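The source may hold more compounds than are shown below. What is called first, only, known or untested is meant among the compounds shown, and "the series" means these compounds.

Measured compounds:
- Compound 1, `Nc1nc(O)nc2c1nc(O)n2Cc1ccccc1`: 1 mg/kg
- Compound 2, `CCCCNc1nc(N)c2nc(O)n(Cc3ccccc3)c2n1`: 0.1 mg/kg
- Compound 3, `CCCCSc1nc(N)c2nc(O)n(Cc3ccccc3)c2n1`: 0.3 mg/kg

All three were tested in a functional assay on the whole organism for activation, with Mus musculus as the target; a higher number here means that more compound is needed for the effect, a lower number that less compound is needed. Compound 3 stands second highest of the three numbers: compound 2 lies closest, with a 3.0-fold higher number from compound 2 to compound 3 (0.48 log units; beyond the scatter), and compound 1 lies furthest, with a 3.3-fold lower number from compound 1 to compound 3 (0.52 log units; beyond the scatter).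

The unmeasured compound 4, `Nc1ncnc2c1nc(O)n2Cc1ccccc1`, differs from compound 3 at one place:
hydrogen in place of butylsulfanyl on an aromatic carbon

Going by the values given here, no measured step removes a group entirely; the three known steps only exchange one group for another at this carbon. Two of them bear on the question indirectly. Hydroxy was the weakest of the tried groups: a 10-fold lower number from compound 1 to compound 2 (1.00 log units; beyond the scatter) and a 3.3-fold lower number from compound 1 to compound 3 (0.52 log units; beyond the scatter) show that both butyl-bearing groups gave lower numbers than hydroxy. Removing the butylsulfanyl group altogether leaves the shared core without any group at that carbon, and the expectation is therefore a rise in the number, roughly back towards where compound 1 stands, though a hydrogen is not a hydroxy group and the true step could be smaller or larger.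

Compound 4 is expected to show a 3.3-fold higher number from compound 3 to compound 4 (0.52 log units; beyond the scatter) in this assay. The estimated value of compound 4 is 1 mg/kg, with a likely range from 0.3 mg/kg to 3 mg/kg.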

Compound 4, minimum effective dose: 30 mg/kg
Compound 4: middle estimate off by 30-fold (1.48 log units), on the low side; the measured number lies above the stated range.
By their numbers in this assay, from the lowest: compound 2; then compound 3; then compound 1; then compound 4.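

In this assay, leaving this aromatic carbon, the one between two ring nitrogen atoms, with only a hydrogen is far more costly than any exchange among the earlier groups, as both butyl-bearing compounds show (a 100-fold higher number from compound 3 to compound 4 (2.00 log units; beyond the scatter); a 300-fold higher number from compound 2 to compound 4 (2.48 log units; beyond the scatter)). Going by these compounds alone, compound 1 had the highest number of the earlier three, yet its hydroxy group still compares well with hydrogen (a 30-fold higher number from compound 1 to compound 4 (1.48 log units; beyond the scatter)), so the earlier compounds gave too narrow a picture of how much this position can matter: the presence of a group here counts, not only the butyl chain. Nothing in the information available explains why the hydrogen compound needs so much more compound for the effect.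

The compounds shown leave open how much of the gain comes from having any group on this carbon and how much from the butyl chain, a question that a simple amino or methyl group here would help to answer. On these data alone, it also remains open whether a longer chain, such as hexylamino, or a ring-bearing group, such as benzylamino, would lower the number further or raise it.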